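Ethyl gives way to tert-butyl in compound 3

The source may report more compounds than this note shows. Statements on the series, on what has been measured and on what is new or still open speak of the compounds shown alone.

compound 1 `CCCNc1nc(C)nc(O)c1C#N` at 1900 nM
compound 2 `CCc1nc(O)c(C#N)c(NCc2cccnc2)n1` at 5500 nM

In a functional assay (muscle tissue) with Felis catus as the target (on this read-out higher numbers stand for an effect only at larger amounts of compound and lower numbers for an effect already at smaller amounts), compound 2 gives 5500 nM as the higher of the two numbers, and its gap to compound 1 lies beyond the scatter. Compound 3 `CC(C)(C)c1nc(O)c(C#N)c(NCc2cccnc2)n1` carries tert-butyl in place of ethyl on an aromatic carbon, between two ring nitrogen atoms, as tert-butyl in place of ethyl on an aromatic carbon counts. Among the measured compounds shown here, no measured pair shows this change, so no step beyond the scatter is expected in this assay here. The estimated change is a 1.1-fold higher number from compound 2 to compound 3 (0.04 log units; within the scatter) and remains small. For compound 3 the expected value is 6000 nM within an estimated range of 1800 nM to 20000 nM in this read-out.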

Compound 3, half-maximal effective concentration: 55000 nM
Compound 3: the middle estimate sits 9.2-fold (0.96 log units) below what was measured; measured number outside the range, above it.
By their numbers in this assay, from the lowest: compound 1; then compound 2; then compound 3.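

Among the compounds shown here, compound 2 and compound 3 form the first pair that isolates this position, on an aromatic carbon between two ring nitrogen atoms, and in this assay the swap of ethyl for tert-butyl gives a 10-fold higher number from compound 2 to compound 3 (1.00 log units; beyond the scatter). The position therefore does not tolerate every carbon group alike, even though the change adds only carbon, with no ring, hydrogen-bond donor, hydrogen-bond acceptor or net charge involved. Nothing at hand accounts for this step. From the compounds shown here alone, whether isopropyl or a longer chain would behave like ethyl or like tert-butyl stays open. So does the effect of an amine here.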